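Bromo at the aromatic ring: compound 2 to compound 3

A few compounds are considered here, and "the series" means these few. Any claim that something is new, unique, unknown or untested is made for them only; others in the source may bear on it.

Compound 2 `CC1(C)[C@H]2CC[C@]1(C)N(Cc1cn(-c3ccccc3)nn1)C(=O)C2` gives 90 nM in a functional assay on HepG2 cells (Homo sapiens) for inhibition, read by MTT assay, with a stated time of 24 h (on this read-out higher numbers stand for weaker inhibition and lower numbers for stronger inhibition), and compound 1 `CC1(C)[C@H]2CC[C@]1(C)N(Cc1cn(-c3ccccc3F)nn1)C(=O)C2` gives 60 nM in this assay; the two lie within the scatter of each other, the only step shown being a 1.5-fold higher number from compound 1 to compound 2 (0.18 log units; within the scatter). Compound 3 `CC1(C)[C@H]2CC[C@]1(C)N(Cc1cn(-c3cccc(Br)c3)nn1)C(=O)C2` differs from compound 2 by bromo in place of hydrogen on an aromatic carbon. No measured step bears directly on a bromo at this position; the one step shown was itself within the scatter. Compound 3 is therefore expected to sit near compound 2, with a step of a 1.1-fold lower number from compound 2 to compound 3 (0.05 log units; within the scatter), at an estimated 80 nM, between 30 nM and 250 nM.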

Compound 3, half-maximal inhibitory concentration: 20 nM
Compound 3: the middle estimate sits 4.0-fold (0.60 log units) above what was measured; measured number outside the range, below it.
By their numbers in this assay, from the lowest: compound 3; then compounds 1 and 2 (each within the scatter of the next).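

Bromo on this aromatic carbon, meta to a large group, is the first change on the ring to move the number beyond the scatter in this assay, with a 4.5-fold lower number from compound 2 to compound 3 (0.65 log units; beyond the scatter). The 3-bromophenyl group also stands apart from 2-fluorophenyl, with a 3.0-fold lower number from compound 1 to compound 3 (0.48 log units; beyond the scatter), whereas the step between fluoro and hydrogen had stayed within the scatter. No measurement at hand accounts for this result. From the compounds shown here alone, what a methoxy group, an amine or a carboxylic acid would do on this same aromatic carbon stays open, as does whether bromo on another carbon of the ring would give a similar step.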